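This account rests on a few compounds, and the source may have more. Where it says the series, first, only, none or still open, it means among the compounds named here.

Measured compounds in an assay on HEK293 cells for activation of Kir3.1/Kir3.2 (Homo sapiens), read by thallium flux; a lower number here means a smaller maximal response, a higher number a larger maximal response:

- compound 1, `Cc1cc(NC(=O)Cn2nnc(-c3cccnc3)n2)n(C2CCCCC2)n1`: 96%
- compound 2, `Cc1cc(NC(=O)Cn2nnc(-c3ccc(Cl)c(Cl)c3)n2)n(C2CCCCC2)n1`: 84%
- compound 3, `Cc1cc(NC(=O)Cn2nnc(-c3cccc(F)c3)n2)n(C2CCCCC2)n1`: 96%

Compound 3 stands level with compound 1 in this assay; the two together give the highest of the three numbers. The step of no change at the digits printed from compound 1 to compound 3 (within the scatter) is within the scatter. The step of a number 12 percentage points higher from compound 2 to compound 3 (beyond the scatter) is beyond it, and the matching step a number 12 percentage points lower from compound 1 to compound 2 (beyond the scatter) shows the same gap from the other side. Compound 2 is thus the only one of the three that sits lower in this assay.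

Compound 4, `Cc1cc(NC(=O)Cn2nnc(-c3ccccc3F)n2)n(C2CCCCC2)n1`, is not yet measured. It differs from compound 3 as follows: 2-fluorophenyl in place of 3-fluorophenyl on an aromatic carbon. Among the compounds with values here, none of the measured steps moves a fluorine within the same ring; the steps so far exchange the whole group for another group, and the only step beyond the scatter involves 3,4-dichlorophenyl. Within the data shown here, the steps that bear most on compound 4 are the small ones around compound 3, no change at the digits printed from compound 1 to compound 3 (within the scatter) within the scatter, and the modest one, a number 12 percentage points higher from compound 2 to compound 3 (beyond the scatter), which sets the largest movement seen in this assay so far.

The expected step is therefore a number 4 percentage points lower from compound 3 to compound 4 (within the scatter), no change beyond the scatter. Compound 4 is estimated at 92% in this assay, with a range from 78% to 102%.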

Compound 4, largest response reached (Emax), in percent of the reference or control that the assay uses: 88%
Compound 4: the middle estimate sits 4 percentage points above what was measured, within the range that was stated.
By their numbers in this assay, from the lowest: compounds 2, 4, 1 and 3 (each within the scatter of the next, the first and the last beyond it).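

In this assay, within the data shown here, 2-fluorophenyl in place of 3-fluorophenyl, on the aromatic carbon of the five-membered aromatic ring with 4 nitrogen, gives a number 8 percentage points lower from compound 3 to compound 4 (within the scatter); this is the only step that keeps the same atoms and joins them differently, so at this position the site of the single fluorine on the phenyl ring produces no step beyond the scatter. Compound 4 also cannot be placed with either of the two levels seen so far: the series holds both a number 8 percentage points lower from compound 1 to compound 4 (within the scatter) and a number 4 percentage points higher from compound 2 to compound 4 (within the scatter), although a number 12 percentage points lower from compound 1 to compound 2 (beyond the scatter) lies beyond the scatter. Nothing available bears on what lies behind these numbers.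

The compounds shown leave open whether a ring carrying an amine, a carboxylic acid or a methoxy group at this position would hold the response of compound 3 or give a step beyond the scatter. They also leave open whether the small step seen with the fluorine move would persist with a different group on the nitrogen of the shared core, and how these compounds compare on any read-out other than the largest response.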